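Phenyl for isopropyl on a quinoline-like core series

This account rests on a few compounds, and the source may have more. Where it says the series, first, only, none or still open, it means among the compounds named here.

Measured so far:
compound 1, `COc1cccc(CNCCCNc2ccnc3cc(Oc4ccccc4)ccc23)c1O`, gives 6800 nM
compound 2, `CC(C)Cc1ccc2c(NCCCNCc3ccco3)ccnc2c1`, gives 16000 nM

Both were tested in an ADME assay on HepG2 cells (Homo sapiens) for cytotoxicity, read by luminescence, CellTiter-Glo and ATP content, with a stated time of 72 h; a lower number here means that less compound is needed, a higher number that more compound is needed for the effect. Compound 2 stands at the higher of the two numbers: its value of 16000 nM sits beyond the scatter from the value of compound 1, which is 6800 nM. Compound 2 therefore needs more substance for the same effect on the cells than compound 1 does.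

Compound 3, `c1ccc(Cc2ccc3c(NCCCNCc4ccco4)ccnc3c2)cc1`, has not yet been measured. It differs from compound 2 in one place: phenyl in place of isopropyl on a saturated chain carbon bound to an aromatic carbon. Among the compounds with values here, no step between measured compounds shows what such a change does here, so the expectation rests on compound 2 alone. A small step is expected, downward if anything, but most likely no step beyond the scatter.

Compound 3 is estimated to give 12000 nM, with a range from 5000 nM to 30000 nM, which means an expected step of a 1.3-fold lower number from compound 2 to compound 3 (0.12 log units; within the scatter).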

Compound 3, half-maximal effective concentration: 16000 nM
For compound 3 the middle estimate is 1.3-fold (0.12 log units) below the measured one; the measured number falls inside the stated range.
By their numbers in this assay, from the lowest: compound 1; then compounds 2 and 3 (each within the scatter of the next).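

In this assay, putting phenyl in place of isopropyl on a saturated chain carbon bound to an aromatic carbon gives no change at the digits printed from compound 2 to compound 3 (within the scatter). Within the data shown here, this is the first direct reading of this position: read one bond further out, isobutyl and benzyl cannot be told apart here, so the added aromatic ring leaves the number for this pair where it was. No measurement shown offers an explanation for this outcome.

Still open, from the compounds shown here alone, is whether an amine, a carboxylic acid or a longer chain at this place would move the number beyond the scatter. Also open, going by these compounds, is whether the same change would read alike with another side chain, since compound 1 differs from compound 2 in more than one place and offers no direct comparison.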